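Thioether benzamides: methoxy to methyl on the outer ring

A few compounds are considered here, and "the series" means these few. Any claim that something is new, unique, unknown or untested is made for them only; others in the source may bear on it.

Measured compounds:
compound 1 `Nc1ccccc1NC(=O)/C=C/c1ccc(CSc2ccc(F)cc2)cc1`: 3670 nM
compound 2 `COc1ccc(SCc2ccc(C(=O)Nc3ccccc3N)cc2)cc1`: 3010 nM

Both compounds have been run in a functional assay on A-375 cells (Homo sapiens) for antiproliferative activity, read by CCK-8 assay, with a stated time of 72 h; on this read-out higher numbers stand for weaker inhibition and lower numbers for stronger inhibition. In this assay compound 1 gives 3670 nM, and compound 2 gives 3010 nM. The two values sit within the usual scatter of each other, so compound 2 does not stand apart from compound 1 on what has been measured; the pair shares the benzamide to ortho-aminophenyl motif but differs in the linker, so the two numbers say nothing about a single change.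

Compound 3 `Cc1ccc(SCc2ccc(C(=O)Nc3ccccc3N)cc2)cc1` is the next one for this assay. It differs from compound 2 in one place: methyl in place of methoxy on an aromatic carbon. Going by the values given here, no measured pair carries a change of this kind, so there is nothing to set the size of the step against. The expectation is that the step from compound 2 to compound 3 stays within the scatter, without a clear direction, which the estimate a 1.0-fold lower number from compound 2 to compound 3 (0.00 log units; within the scatter) reflects. Compound 3 is therefore estimated at 3000 nM, with a range from 1400 nM to 6500 nM.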

Compound 3, half-maximal inhibitory concentration: 3700 nM
Beside the measured number, compound 3's estimate is 1.2-fold (0.09 log units) below it; the measured number falls inside the stated range.
By their numbers in this assay, from the lowest: compounds 2, 1 and 3 (each within the scatter of the next).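

In this assay, going by these compounds alone, the change from 4-methoxyphenyl to 4-methylphenyl provides the first single-place step, a 1.2-fold higher number from compound 2 to compound 3 (0.09 log units; within the scatter). On this aromatic carbon, para to a large group, methyl in place of methoxy therefore leaves the read-out within the scatter, even though the oxygen and the hydrogen-bond acceptor of methoxy are gone. No supporting data bear on why this step stays so small.

A single step within the scatter does not show how far this position tolerates change in general, and an amine or a carboxylic acid here could give a different reading. Compound 1 differs from compound 2 in more than one place, so it does not help to settle this question.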